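The source may report more compounds than this note shows. Statements on the series, on what has been measured and on what is new or still open speak of the compounds shown alone.

Values in an ADME assay on MT4 cells (Homo sapiens) for cytotoxicity, read by MTT assay, with a stated time of 96 h; a higher number here means that more compound is tolerated, a lower number that less compound is tolerated:
compound 1 `C/C(=N\NC(N)=S)c1ccc2c(c1)nc(-c1ccccc1)n2C1CCCCC1`: 20000 nM
compound 2 `C/C(=N\NC(N)=S)c1ccc2c(c1)nc(-c1ccc(Cl)cc1)n2C1CCCCC1`: 17000 nM
compound 3 `COc1ccc(-c2nc3cc(/C(C)=N/NC(N)=S)ccc3n2C2CCCCC2)cc1`: 39000 nM

Compound 3 is set apart from only one of the other two. The step that does so is a 2.3-fold higher number from compound 2 to compound 3 (0.36 log units; beyond the scatter), whereas the comparison with compound 1 gives a 2.0-fold higher number from compound 1 to compound 3 (0.29 log units; within the scatter).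

The next step leads to compound 4 `C/C(=N\NC(N)=S)c1ccc2c(c1)nc(-c1ccccn1)n2C1CCCCC1`, with pyridin-2-yl in place of 4-methoxyphenyl on an aromatic carbon. Among the measured compounds shown here, no measured step covers this exchange, and no compound measured so far has a hetero atom in that six-membered aromatic ring. The nearest evidence comes from substituent changes on the phenyl group, namely a 1.2-fold lower number from compound 1 to compound 2 (0.07 log units; within the scatter) and a 2.0-fold higher number from compound 1 to compound 3 (0.29 log units; within the scatter). Both are small, so the series has so far moved little in this assay with changes at this part of the structure. Compound 4 has no methoxy group, and neither does compound 1 at 20000 nM, so an expectation near that value is reasonable. The direction rests on this one comparison and remains tentative.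

The expected change is small and towards a lower number: a 1.6-fold lower number from compound 3 to compound 4 (0.21 log units; within the scatter).

For compound 4 the estimated value is 24000 nM, with an expected range from 10000 nM to 50000 nM.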

Compound 4, half-maximal cytotoxic concentration: 23000 nM
The estimate for compound 4 lay 1.0-fold (0.02 log units) above the measured number, and the stated range covers the measured number.
By their numbers in this assay, from the lowest: compounds 2, 1, 4 and 3 (each within the scatter of the next, the first and the last beyond it).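

Working notes on the aryl group on the aromatic carbon of the five-membered aromatic ring, in this assay: pyridin-2-yl is the first six-membered aromatic ring with a hetero atom at this place, and compound 4 stays within the scatter of all three carbon-only aryl compounds (a 1.7-fold lower number from compound 3 to compound 4 (0.23 log units; within the scatter); a 1.4-fold higher number from compound 2 to compound 4 (0.13 log units; within the scatter); a 1.2-fold higher number from compound 1 to compound 4 (0.06 log units; within the scatter)). Among the compounds shown here, the only step in the set beyond the scatter remains the one between the two substituted phenyl compounds (a 2.3-fold higher number from compound 2 to compound 3 (0.36 log units; beyond the scatter)), and compound 4 does not separate from either of them, so a ring nitrogen in place of a ring carbon, with the para-type substituents absent, leaves this read-out essentially where the phenyl compounds already sit. No measurement is available that would explain this flat response.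

Still open, on these data alone, is whether a group of another kind on this aryl ring, such as an amine or a carboxylic acid, or a saturated ring such as morpholine in place of the aryl group, would move the number beyond the scatter. The cyclohexyl group is also the same in all four compounds, so a shorter chain such as ethyl at that place remains an untested variable for this series.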